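Propargyloxy ether at the ring sulfonamide nitrogen: compound 4

The source may report more compounds than this note shows. Statements on the series, on what has been measured and on what is new or still open speak of the compounds shown alone.

The series shares the core seen in compound 1 `O=C1c2ccccc2N(COCc2ccccc2)S(=O)(=O)N1Cc1ccccc1`, which carries a benzyloxy group on the saturated chain carbon bound to the sulfonamide nitrogen in the ring. In a functional assay on HEL cells (Homo sapiens) (on this read-out lower numbers stand for higher toxicity in this test and higher numbers for lower toxicity in this test), compound 1 gives 122000 nM. Compound 2 `O=C(OCOCN1c2ccccc2C(=O)N(Cc2ccccc2)S1(=O)=O)c1ccccc1` has benzoyloxy in place of phenyl on a saturated chain carbon bound to an oxygen on a saturated carbon; in this assay compound 2 gives 110000 nM, and the step of a 1.1-fold lower number from compound 1 to compound 2 (0.04 log units; within the scatter). Compound 3 `O=C1c2ccccc2N(Cc2ccccc2)S(=O)(=O)N1Cc1ccccc1` has phenyl in place of benzyloxy on the saturated chain carbon bound to the sulfonamide nitrogen in the ring. For compound 3 only a limit is recorded in this assay, > 50000 nM. The step that the limit leaves unreadable from compound 1 to compound 3 stays unreadable since compound 3 sits at the limit of > 50000 nM in this assay, at which 1 of the 3 values shown sits.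

Compound 4 `C#CCOCN1c2ccccc2C(=O)N(Cc2ccccc2)S1(=O)=O` differs from compound 3 as follows: propargyloxy in place of phenyl on a saturated chain carbon bound to a sulfonamide nitrogen in a ring. This restores an oxygen-linked group at the same place as in compound 1. Within the data shown here, the only step at this place, from compound 1 to compound 3, cannot be sized, and the change at the ether end, from compound 1 to compound 2, lay within the scatter. No direction beyond the scatter is therefore expected for compound 4 in this assay. For compound 4 a value close to that of compound 1 is estimated, 100000 nM, within 40000 nM to 250000 nM. The estimated step is a step that the limit leaves unreadable from compound 3 to compound 4.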

Compound 4, minimum cytotoxic concentration: 140000 nM
Estimate against measurement, compound 4: 1.4-fold (0.15 log units) below; the measured number falls inside the stated range.
By their numbers in this assay, from the lowest: compounds 2, 1 and 4 (each within the scatter of the next).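

In this assay, the end of the ether chain now tolerates a small group without a ring. On the saturated chain carbon bound to an oxygen on a saturated carbon, replacing phenyl with ethynyl gives a 1.1-fold higher number from compound 1 to compound 4 (0.06 log units; within the scatter), and replacing benzoyloxy with ethynyl gives a 1.3-fold higher number from compound 2 to compound 4 (0.10 log units; within the scatter). Compounds 1, 2 and 4 therefore stand within the scatter of one another despite carrying phenyl, benzoyloxy and ethynyl at this place, so for these three compounds the aromatic ring at this end makes no readable difference to the number. The steps involving compound 3 cannot be read, as its entry is a limit: the limit of > 50000 nM in this assay, at which 1 of the 4 values shown sits.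

From the compounds shown here alone, it remains open whether an oxygen-linked group on the saturated chain carbon bound to the ring sulfonamide nitrogen differs at all from the phenyl of compound 3. Going by these compounds, it is also open whether a primary amine, a carboxylic acid or a longer alkyl chain at the ether end would stay within the scatter of compounds 1, 2 and 4.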